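Fluoro on the sulfamoyl ring: forecast for compound 4

A few compounds are considered here, and "the series" means these few. Any claim that something is new, unique, unknown or untested is made for them only; others in the source may bear on it.

Measured so far in an assay on cells for inhibition of sodium channel protein type 3 subunit alpha (Homo sapiens), read by electrophysiology; on this read-out lower numbers stand for stronger inhibition and higher numbers for weaker inhibition:
Compound 1 `O=C(NCc1ccc(C(F)(F)F)cc1)c1ccc(S(=O)(=O)Nc2nccs2)cc1` — 147 nM
Compound 2 `O=C(NCc1ccc(OC(F)(F)F)cc1)c1ccc(S(=O)(=O)Nc2nccs2)cc1` — 197 nM
Compound 3 `O=C(NCc1ccc(OC(F)(F)F)c(Cl)c1)c1ccc(S(=O)(=O)Nc2nccs2)cc1` — 20 nM

Compound 3 stands lowest of the three numbers in this assay; compound 1 and compound 2 both give higher numbers than compound 3, and the step from compound 1 to compound 2, a 1.3-fold higher number from compound 1 to compound 2 (0.13 log units; within the scatter), stays within the scatter, whereas the step from compound 2 to compound 3, a 9.9-fold lower number from compound 2 to compound 3 (0.99 log units; beyond the scatter), lies beyond it. Both of those steps alter the substituents on the ring that carries the benzylic amide nitrogen.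

Compound 4 `O=C(NCc1ccc(OC(F)(F)F)c(Cl)c1)c1ccc(S(=O)(=O)Nc2nccs2)c(F)c1` is compound 3 with one change: fluoro in place of hydrogen on an aromatic carbon. This ring, the one bearing the (1,3-thiazol-2-yl)sulfamoyl group, is untouched in every measured pair, so neither a 1.3-fold higher number from compound 1 to compound 2 (0.13 log units; within the scatter) nor a 9.9-fold lower number from compound 2 to compound 3 (0.99 log units; beyond the scatter) bears directly on the new step. Nothing in the measured set points to a shift beyond the scatter in either direction; the working expectation is a number close to that of compound 3.

Compound 4 is therefore estimated at 20 nM in this assay, expected to fall between 8 nM and 50 nM. The expected step from compound 3 to compound 4 is no change at the digits printed from compound 3 to compound 4 (within the scatter), within the scatter.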

Compound 4, half-maximal inhibitory concentration: 11 nM
Estimate against measurement, compound 4: 1.8-fold (0.26 log units) above, and the stated range covers the measured number.
By their numbers in this assay, from the lowest: compounds 4 and 3 (each within the scatter of the next); then compounds 1 and 2 (each within the scatter of the next).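

In this assay, fluoro in place of hydrogen on an aromatic carbon ortho to the (1,3-thiazol-2-yl)sulfamoyl group gives a 1.8-fold lower number from compound 3 to compound 4 (0.26 log units; within the scatter). Among the compounds shown here, this is the first reading from the ring bearing that group, as the earlier steps changed only the ring carrying the benzylic amide nitrogen, and it shows that this position takes a single fluorine atom without a shift beyond the scatter, at least with the chloro and trifluoromethoxy substituents of compound 3 in place. No measurement shown offers an explanation for this result.

The compounds shown leave open whether a larger or differently functionalised group at this position, such as chloro, methoxy or an amine, would also stay within the scatter of compound 3, and whether the other aromatic carbons of this ring would respond in the same way. They also leave open whether fluoro at this position would give a similar step on compound 2, which carries hydrogen where compound 3 carries chloro.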